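Carboxy in place of dimethylamino on the shared core

The source may hold more compounds than are shown below. What is called first, only, known or untested is meant among the compounds shown, and "the series" means these compounds.

Measured compounds:
compound 1, `COc1ccc(-c2cc(C(=O)c3ccccc3)c(N)s2)cc1`: 14%
compound 2, `CN(C)c1ccc(-c2cc(C(=O)c3ccccc3)c(N)s2)cc1`: 29%

In an assay on CHO cells for positive allosteric modulation of adenosine receptor A1 (Homo sapiens), read by ERK phosphorylation, tested at 10 uM (on this read-out lower numbers stand for a stronger effect and higher numbers for a weaker effect at the one concentration tested), compound 1 gives 14%. In this assay compound 2 gives 29%, and on these two numbers compound 2 stands highest; its nearest neighbour is compound 1, and the step of a number 15 percentage points higher from compound 1 to compound 2 (beyond the scatter) is beyond the scatter.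

Compound 3, `Nc1sc(-c2ccc(C(=O)O)cc2)cc1C(=O)c1ccccc1`, has not been measured in this assay. It differs from compound 2 in one place: carboxy in place of dimethylamino on an aromatic carbon. Among the compounds with values here, of the measured steps, only the step of a number 15 percentage points higher from compound 1 to compound 2 (beyond the scatter) bears on it at all, and only loosely: it shows that exchanging the group para to the large group on the shared core moved the number by a modest amount, but neither of the measured compounds carries a carboxy group, so no measured step speaks directly to the change from compound 2 to compound 3. On that thin basis, compound 3 is expected to move by a number 16 percentage points higher from compound 2 to compound 3 (beyond the scatter), a step of uncertain direction and size. The estimate for compound 3 in this assay is 45%, with a range from 15% to 80%.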

Compound 3, a percentage reported as activity, at one concentration (the size of the read-out at that concentration, not a potency): 27%
For compound 3 the middle estimate is 18 percentage points above the measured one, and the stated range covers the measured number.
By their numbers in this assay, from the lowest: compound 1; then compounds 3 and 2 (each within the scatter of the next).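

In this assay, carboxy in place of dimethylamino on an aromatic carbon, para to a large group, gives a number 2 percentage points lower from compound 2 to compound 3 (within the scatter), so this position does not separate the two groups, even though carboxy enters with 1 hydrogen-bond donor and dimethylamino leaves with 0 hydrogen-bond donors. Methoxy, by contrast, stays apart from carboxy, with a number 13 percentage points higher from compound 1 to compound 3 (beyond the scatter) of modest size, and together with a number 15 percentage points higher from compound 1 to compound 2 (beyond the scatter) this leaves compound 1 alone with the lower number among the three, which on this read-out stands for the stronger effect. Nothing available on these compounds offers an explanation for these numbers.

Whether the lower number of compound 1 belongs to methoxy in particular stays open, since the compounds shown include no ethoxy, hydroxy or unsubstituted carbon at this position for comparison. They also leave open whether a methyl ester or a primary amide in place of carboxy, or a primary amine in place of dimethylamino, would read with compound 1 or with compound 2 and compound 3.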